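Working notes: from compound 3 to compound 4

A few compounds are considered here, and "the series" means these few. Any claim that something is new, unique, unknown or untested is made for them only; others in the source may bear on it.

In a functional assay on HeLa cells (Homo sapiens) for cytotoxicity, read by MTT assay (on this read-out higher numbers stand for weaker inhibition and lower numbers for stronger inhibition), compound 1 (`O=C1CC(CCc2ccccc2)SS1`) gives 258000 nM, compound 2 (`CC1(C)O[C@H]([C@H]2COC(C)(C)O2)[C@@H](C2CC(=O)SS2)O1`) gives 35900 nM and compound 3 (`CC(C)(C)[Si](C)(C)O[C@@H]1[C@H](O[Si](C)(C)C(C)(C)C)[C@@H](C2CC(=O)SS2)O[C@H]1n1ccc(=O)[nH]c1=O`) gives 10000 nM. Compound 3 thus holds the lowest of the three numbers, and its gaps to both other compounds lie beyond the scatter. For the measured compounds named here, these three compounds differ widely in their substituents, and no measured pair isolates a single change.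

Compound 4 (`CC(C)(C)[Si](C)(C)O[C@@H]1[C@H](O[Si](C)(C)C(C)(C)C)[C@@H](C2CC(=O)S[S+]2[O-])O[C@H]1n1ccc(=O)[nH]c1=O`) departs from compound 3 in one place: a group of 7 heavy atoms (3 carbon, 2 oxygen, 2 sulfur; one five-membered non-aromatic ring with 2 hetero atoms) in place of a group of 6 heavy atoms (3 carbon, 1 oxygen, 2 sulfur; one five-membered non-aromatic ring with 2 hetero atoms), on a saturated ring carbon. The exchange sits on a saturated ring carbon of a five-membered non-aromatic ring with 1 oxygen, and the rest of the structure stays the same. Going by the values given here, with no measured precedent for this exchange, the expectation is tentative: a modest shift in this assay towards stronger inhibition, possibly not beyond the scatter. The estimated step is a 1.7-fold lower number from compound 3 to compound 4 (0.22 log units; within the scatter). Compound 4 is expected at 6000 nM, with an estimated range of 1500 nM to 25000 nM.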

Compound 4, half-maximal inhibitory concentration: 3680 nM
Estimate against measurement, compound 4: 1.6-fold (0.21 log units) above; measured number inside the range.
By their numbers in this assay, from the lowest: compound 4; then compound 3; then compound 2; then compound 1.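

In this assay, the series now has its first pair differing in one place, and it shows a 2.7-fold lower number from compound 3 to compound 4 (0.43 log units; beyond the scatter) when the group of 7 heavy atoms replaces the group of 6 heavy atoms on the saturated ring carbon next to the ring oxygen. The step is modest but beyond the scatter, so this position accepts the extra oxygen in the five-membered group without a loss on this read-out, and compound 4 now holds the lowest number of the four. Nothing on hand bears on the reason for this step.

On these data alone, whether the same exchange carries over to the cores of compound 1 and compound 2 stays open. Also open, as far as these compounds go, is how this carbon responds to a group of another kind, such as an amine or a carboxylic acid, in place of the five-membered group.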